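Ethyl in Place of Hydrogen: From Compound 1 to Compound 3

The source may report more compounds than this note shows. Statements on the series, on what has been measured and on what is new or still open speak of the compounds shown alone.

Compound 1 `O=C1CS/C(=N\N=C/c2cccnc2)N1Cc1ccco1` was tested in a functional assay on HFL1 cells (Homo sapiens) for inhibition, read by sulforhodamine B assay, with a stated time of 48 h (a lower number here means a smaller maximal response, a higher number a larger maximal response), and gave 69.4%. For the measured compounds named here, this stands as the higher of the two numbers known so far, since compound 2 `O=C1N=C(Nc2ccc(O)cc2)S/C1=C\c1ccc(Cl)cc1` gives 46.1% in this assay, a value beyond the scatter below that of compound 1. Compound 3 `CCC1S/C(=N\N=C/c2cccnc2)N(Cc2ccco2)C1=O` is not yet measured. It differs from compound 1 in a single place: ethyl in place of hydrogen on a saturated ring carbon. Going by the values given here, no pair of measured compounds shows what such a change does here, so no direction can be read from the data; the expectation is a step no larger than the scatter a number 4.4 percentage points lower from compound 1 to compound 3 (within the scatter). Compound 3 is accordingly estimated at 65%, with a range from 45% to 85%.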

Compound 3, largest response reached (Emax), in percent of the reference or control that the assay uses: 44.7%
Compound 3: middle estimate off by 20.3 percentage points, on the high side; the measured number lies below the stated range.
By their numbers in this assay, from the lowest: compounds 3 and 2 (each within the scatter of the next); then compound 1.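

Ethyl in place of hydrogen on this saturated ring carbon, next to the ring sulfur, is the only single change shown in this assay, and it gives a number 24.7 percentage points lower from compound 1 to compound 3 (beyond the scatter) and so shows that the maximal response depends on what this carbon carries. No measurement at hand explains the step. With ethyl the only group shown at this carbon, it remains open whether methyl, a longer chain such as propyl, or an amine there would move the response in the same direction or to the same extent.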